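A few compounds are considered here, and "the series" means these few. Any claim that something is new, unique, unknown or untested is made for them only; others in the source may bear on it.

Compound 1 `CN1CCCN(CCNc2nccc(-c3c(-c4cccc(O)c4)nc4sccn34)n2)S1(=O)=O`: 12900 nM
Compound 2 `O=S(=O)(NCCCNc1nccc(-c2c(-c3cccc(O)c3)nc3sccn23)n1)c1cccc(F)c1`: 10200 nM
Compound 3 `O=S(=O)(NCCNc1nccc(-c2c(-c3cccc(O)c3)nc3sccn23)n1)c1ccc(F)cc1`: not yet measured

In a functional assay on M14 cells (Homo sapiens) for inhibition, read by sulforhodamine B assay, with a stated time of 48 h (a lower number here means a stronger inhibitor of growth, a higher number a weaker inhibitor of growth), compound 2 gives 10200 nM, within the scatter of compound 1 at 12900 nM, so the two cannot be ranked. The move to compound 3 is ((4-fluorophenyl)sulfonyl)amino in place of (((3-fluorophenyl)sulfonyl)amino)methyl on a saturated chain carbon, two bonds along the chain from a nitrogen on an aromatic ring. In words, ((4-fluorophenyl)sulfonyl)amino stands in place of (((3-fluorophenyl)sulfonyl)amino)methyl on a saturated chain carbon, two bonds along the chain from a nitrogen on an aromatic ring.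

Among the measured compounds shown here, only one measured step bears on this: a 1.3-fold lower number from compound 1 to compound 2 (0.10 log units; within the scatter). That step swapped two quite different groups at this same place and still left this assay within the scatter. It is a single step, so it is thin evidence, but it gives no reason to expect a real shift from this smaller change. The expected result is a 1.1-fold lower number from compound 2 to compound 3 (0.05 log units; within the scatter), with nothing beyond the scatter anticipated. Compound 3 is estimated at 9000 nM, with an expected range of 3500 nM to 20000 nM.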

Compound 3, concentration for total growth inhibition: 15000 nM
For compound 3 the middle estimate is 1.7-fold (0.22 log units) below the measured one; the range from low to high includes it.
By their numbers in this assay, from the lowest: compounds 2, 1 and 3 (each within the scatter of the next).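

In this assay, the step to ((4-fluorophenyl)sulfonyl)amino from (((3-fluorophenyl)sulfonyl)amino)methyl gives a 1.5-fold higher number from compound 2 to compound 3 (0.17 log units; within the scatter), so losing the methyl and going from 3-fluorophenyl to 4-fluorophenyl together produce no shift that can be read. The step from the ring-bearing group of the first compound gives a 1.2-fold higher number from compound 1 to compound 3 (0.07 log units; within the scatter), so all three compounds now sit within the scatter of one another and cannot be ranked, although the group at this place differs markedly among them. Nothing available explains why these numbers stay so close.

Because both changes fall in a single step, the compounds shown cannot separate the effect of the methyl from that of the fluorine's location. They also leave open whether an amine or a carboxylic acid at this place, or a longer chain, would move the number beyond the scatter.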